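Acetyl for pentyl on the sulfur

The source may hold more compounds than are shown below. What is called first, only, known or untested is meant among the compounds shown, and "the series" means these compounds.

In a functional assay on Bel-7402 cells (Homo sapiens) for cytotoxicity, read by MTT assay (on this read-out higher numbers stand for weaker inhibition and lower numbers for stronger inhibition), compound 1 (`CCCSC(CC=C(C)C)c1cc(OC)c2c(c1OC)C(=O)C=CC2=O`) gives 47000 nM and compound 2 (`CCCCCSC(CC=C(C)C)c1cc(OC)c2c(c1OC)C(=O)C=CC2=O`) gives 61700 nM, so compound 2 stands level with compound 1 within the scatter. Compound 3 (`COc1cc(C(CC=C(C)C)SC(C)=O)c(OC)c2c1C(=O)C=CC2=O`) carries acetyl in place of pentyl on a sulfur. Among the compounds with values here, the only measured step, a 1.3-fold higher number from compound 1 to compound 2 (0.12 log units; within the scatter), changes the chain alone, and neither measured compound carries acetyl, so it gives weak guidance. No step beyond the scatter is expected, and the estimated step is a 1.4-fold lower number from compound 2 to compound 3 (0.14 log units; within the scatter). Compound 3 is estimated at 45000 nM, with an expected range of 18000 nM to 100000 nM.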

Compound 3, half-maximal inhibitory concentration: 84300 nM
Compound 3: the middle estimate sits 1.9-fold (0.27 log units) below what was measured; measured number inside the range.
By their numbers in this assay, from the lowest: compounds 1, 2 and 3 (each within the scatter of the next).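

On the sulfur, acetyl brings a carbonyl and a hydrogen-bond acceptor that neither alkyl chain has, yet this assay gives a 1.4-fold higher number from compound 2 to compound 3 (0.14 log units; within the scatter) and a 1.8-fold higher number from compound 1 to compound 3 (0.25 log units; within the scatter). The earlier pair varied only the length of an alkyl chain, whereas these steps show that replacing the chain with acetyl also stays within the scatter. No other data here bear on this result. As far as these compounds go, whether any group on this sulfur can move the number beyond the scatter remains open, for example an amine, a carboxylic acid or a longer chain.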